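A few compounds are considered here, and "the series" means these few. Any claim that something is new, unique, unknown or untested is made for them only; others in the source may bear on it.

Compound 1 `CNCC(=O)Nc1cc(OC)ccc1C(=O)c1ccc(OC)c2c1C=CC(C)(C)O2` and compound 2 `CCNCC(=O)Nc1cc(OC)ccc1C(=O)c1ccc(OC)c2c1C=CC(C)(C)O2` share one core and differ in a single place: methyl in place of hydrogen on a saturated chain carbon bound to an amine nitrogen. In a functional assay on MCF7 cells (Homo sapiens) for antiproliferative activity, read by MTT assay, with a stated time of 48 h (a lower number here means a stronger inhibitor, a higher number a weaker inhibitor), compound 1 gives 3040 nM, while compound 2 gives 7230 nM, so this change produced a 2.4-fold higher number from compound 1 to compound 2 (0.38 log units; beyond the scatter). Compound 3 `C=C(c1ccc(OC)cc1NC(=O)CNC)c1ccc(OC)c2c1C=CC(C)(C)O2` is built on a different core, and the difference between the two cores is not broken down here. In this assay, among the compounds with values here, compound 3 gives 1010 nM, the lowest of the three numbers so far. Compound 4 `C=C(c1ccc(OC)cc1NC(=O)CNCC)c1ccc(OC)c2c1C=CC(C)(C)O2` carries the same change on the core of compound 3: methyl in place of hydrogen on a saturated chain carbon bound to an amine nitrogen. The place of the change is the same in both pairs. The expectation for compound 4 rests on the step of a 2.4-fold higher number from compound 1 to compound 2 (0.38 log units; beyond the scatter), which was modest yet beyond the scatter. The expected step is a 2.4-fold higher number from compound 3 to compound 4 (0.38 log units; beyond the scatter). Compound 4 is therefore estimated at 2400 nM, most likely between 1200 nM and 5000 nM.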

Compound 4, half-maximal inhibitory concentration: 2920 nM
For compound 4 the middle estimate is 1.2-fold (0.09 log units) below the measured one; low and high end bracket the measured number.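

In this assay, ethylamino in place of methylamino gave a 2.9-fold higher number from compound 3 to compound 4 (0.46 log units; beyond the scatter), and this step can be set beside the one seen on the other core: the same change on two cores in this assay, a 2.4-fold higher number (0.38 log units; beyond the scatter) from compound 1 to compound 2 and a 2.9-fold higher number (0.46 log units; beyond the scatter) from compound 3 to compound 4, 1.2-fold (0.08 log units) apart, within the scatter of two such steps. Within these four compounds, then, the change carried from one core to the other in the same direction and at much the same size. Two pairs are too few to make this a general rule, and they do not show why the number goes up.

The compounds shown leave open what a longer chain, such as propyl, would do in the same place. As far as these compounds go, a primary amine in place of methylamino also remains open, on either core.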